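Methyl position change on the propyl-linked aryl group

A few compounds are considered here, and "the series" means these few. Any claim that something is new, unique, unknown or untested is made for them only; others in the source may bear on it.

Values in an ADME assay on MT2 cells (Homo sapiens) for cytotoxicity, read by XTT assay, with a stated time of 4 days; a higher number here means that more compound is tolerated, a lower number that less compound is tolerated:
compound 1 `Cc1ccc(-c2c3c(nc(C)c2[C@H](OC(C)(C)C)C(=O)O)CCN(c2ccccc2)C3)cc1` gives > 40000 nM.
compound 2 `Cc1cccc(CCCN2CCc3nc(C)c([C@H](OC(C)(C)C)C(=O)O)c(-c4cc(F)c5c(c4C)CCCO5)c3C2)c1` gives > 40000 nM.
compound 3 `Cc1ccc(-c2c3c(nc(C)c2[C@H](OC(C)(C)C)C(=O)O)CCN(C(=O)CCc2ccccc2)C3)cc1` gives > 40000 nM.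

Each of these values is a limit of this assay rather than a number: the limit of > 40000 nM in this assay, at which 3 of the 3 values shown sit. Compound 2 therefore stands only at a limit in this assay, and the two further values shown are limits as well. Going by the values given here, the single step among measured compounds that differ in one place, a step that the two limits leave unreadable from compound 1 to compound 3, is left unreadable by the two limits at its ends.

Compound 4 `Cc1ccccc1CCCN1CCc2nc(C)c([C@H](OC(C)(C)C)C(=O)O)c(-c3cc(F)c4c(c3C)CCCO4)c2C1` differs from compound 2 by 2-methylphenyl in place of 3-methylphenyl on a saturated chain carbon, three bonds along the chain from an amine nitrogen in a ring. Among the compounds with values here, no measured step touches this part of the series; the one step that exists concerns the group on the amine nitrogen in the ring, and both of its ends sit at the limit. There is thus nothing in the measured steps that would point to a change of tolerated concentration in either direction, and the expectation for compound 4 rests on compound 2 sitting at the limit together with the other two values, (the limit of > 40000 nM in this assay, at which 3 of the 3 values shown sit).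

The step expected in this assay is a number no higher from compound 2 to compound 4 (the limit leaves the size open), none beyond the scatter. Compound 4 is estimated at 40000 nM, with a range from 20000 nM to 80000 nM, and is expected most likely to be reported again only as a limit.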

Compound 4, half-maximal cytotoxic concentration: > 40000 nM
Compound 4 ended at the assay's limit; the forecaster's own chance of this, stated with the estimate: 85%; the middle value sits exactly at the limit.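

Compound 2 and compound 4 both stand only at a limit in this assay, so no step can be read for 2-methylphenyl in place of 3-methylphenyl: the limit of > 40000 nM in this assay, at which 4 of the 4 values shown sit.

The compounds shown leave open at what concentration any of them stops being tolerated in this assay, and whether 3-(3-methylphenyl)propyl and 3-(2-methylphenyl)propyl differ there at all.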